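A few compounds are considered here, and "the series" means these few. Any claim that something is new, unique, unknown or untested is made for them only; others in the source may bear on it.

Measured in a functional assay on NCI-H522 cells (Homo sapiens) for inhibition, read by sulforhodamine B assay, with a stated time of 48 h, tested at 10 uM; on this read-out lower numbers stand for less inhibition of growth and higher numbers for more inhibition of growth at the one concentration tested:
Compound 1 `CC(=O)c1ccc(NC(=O)Cn2nc(-c3ccc(Cl)cc3)nc2N)cc1`: 28%
Compound 2 `COc1ccc(-c2nc3sc(-c4ccccc4)cn3n2)cc1`: 70%
Compound 3 `COc1ccc(-c2nc3sc(-c4ccc(Cl)cc4)cn3n2)cc1`: 39%

Of these three, compound 2 stands highest, at 70%, clearly above the other two. Compound 4 `c1ccc(-c2nc3sc(-c4ccccc4)cn3n2)cc1` is not yet measured and differs from compound 2 as follows: hydrogen in place of methoxy on an aromatic carbon. For the measured compounds named here, no step that removes a methoxy group has been measured. Going by the values given here, the only measured step bearing on this change is a number 31 percentage points lower from compound 2 to compound 3 (beyond the scatter), a large step beyond the scatter that involves chloro in place of hydrogen on an aromatic carbon. It suggests that one substituent can shift the number substantially, so a moderate fall in this assay is expected, with wide uncertainty. The expected step is a number 15 percentage points lower from compound 2 to compound 4 (beyond the scatter). Compound 4 is estimated at 55%, with an expected range from 30% to 80%.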

Compound 4, percent growth inhibition at one concentration: 19%
The estimate for compound 4 lay 36 percentage points above the measured number; the measured number lies below the stated range.
By their numbers in this assay, from the lowest: compounds 4 and 1 (each within the scatter of the next); then compound 3; then compound 2.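

In this assay, hydrogen in place of methoxy gives a number 51 percentage points lower from compound 2 to compound 4 (beyond the scatter), so the substituent at this place, para to a large group, matters greatly to the read-out. For the compounds shown here, the earlier step, a number 31 percentage points lower from compound 2 to compound 3 (beyond the scatter), concerned a change at a different place, and this is the first measured change at the methoxy position. No available evidence accounts for the size of this fall. The compounds shown leave open whether a hydroxy group, an ethoxy group or an amine at this place would hold the number near that of compound 2, or whether the fall is specific to losing methoxy.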